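Swapping the Halogen on the Aryl Group of Compound 2

A few compounds are considered here, and "the series" means these few. Any claim that something is new, unique, unknown or untested is made for them only; others in the source may bear on it.

Compound 2 `C#CCNC1CCc2c(SCc3ccc(Br)cc3)cccc21` shows the lowest number of the three measured compounds in an ADME assay on isolated protein for inhibition of Amine oxidase [flavin-containing] B (Homo sapiens) (a lower number here means a stronger inhibitor, a higher number a weaker inhibitor), giving 488 nM. Compound 3 `C#CCNC1CCc2c(SCc3ccc(C(F)(F)F)cc3)cccc21` lies nearest to it with 930 nM, and compound 1 `C#CCNC1CCc2c(SCCc3ccc(Br)cc3)cccc21` lies furthest with 1250 nM. Compound 4 `C#CCNC1CCc2c(SCc3cccc(Cl)c3)cccc21` carries 3-chlorophenyl in place of 4-bromophenyl on a saturated chain carbon bound to a sulfur. For the measured compounds named here, the only measured step that alters a substituent on that aryl ring is a 1.9-fold higher number from compound 2 to compound 3 (0.28 log units; within the scatter), and it stayed within the scatter. On that basis the move from compound 2 to compound 4 is expected to be small as well, at most a slightly higher number, a 1.4-fold higher number from compound 2 to compound 4 (0.16 log units; within the scatter). Compound 4 is therefore estimated at 700 nM in this assay, with a range from 250 nM to 2000 nM.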

Compound 4, half-maximal inhibitory concentration: 1090 nM
Beside the measured number, compound 4's estimate is 1.6-fold (0.19 log units) below it; low and high end bracket the measured number.
By their numbers in this assay, from the lowest: compounds 2, 3, 4 and 1 (each within the scatter of the next, the first and the last beyond it).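

In this assay, the step to 3-chlorophenyl, a 2.2-fold higher number from compound 2 to compound 4 (0.35 log units; beyond the scatter), is the only change on this aryl ring shown so far that lies beyond the scatter, whereas a 1.9-fold higher number from compound 2 to compound 3 (0.28 log units; within the scatter) stayed within it. The number at this position can therefore shift with the ring's substituent, though the shift here is modest. No measured evidence is available to explain this shift.

This step changes both the halogen and its place on the ring, and the compounds shown do not separate the two. On these data alone, how a methoxy group or an amine on this ring would compare also remains open.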